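Removing a Side Chain on Two Related Cores

A few compounds are considered here, and "the series" means these few. Any claim that something is new, unique, unknown or untested is made for them only; others in the source may bear on it.

Compound 1 `CC(C)=CCC/C(C)=C/C[C@@H]1C[C@]2(CC=C(C)C)C(=O)[C@@](CC=C(C)C)(C(=O)C(C(=O)c3ccc(O)c(O)c3)=C2O)C1(C)C`: > 20 ug/mL
Compound 2 `CC(C)=CCC/C(C)=C/C[C@@H]1C[C@@]2(C/C=C(\C)CCC=C(C)C)C(=O)CC(=O)[C@](CC=C(C)C)(C2=O)C1(C)C`: > 20 ug/mL
Compound 3 `CC(C)=CCC/C(C)=C/C[C@@H]1C[C@]2(C/C=C(\C)CCC=C(C)C)C(=O)[C@@](CC=C(C)C)(C(=O)C(C(=O)c3ccc(O)c(O)c3)=C2O)C1(C)C`: 4.05 ug/mL

In a functional assay on SGC-7901 cells (Homo sapiens) for inhibition (on this read-out higher numbers stand for weaker inhibition and lower numbers for stronger inhibition), compound 3 gives 4.05 ug/mL. For compound 1 the assay reports only a limit, > 20 ug/mL. For compound 2 it likewise reports only a limit, > 20 ug/mL. The change hydrogen in place of 3-methylbut-2-en-1-yl on a saturated chain carbon bound to a double-bonded chain carbon produced an at least 4.9-fold higher number from compound 3 to compound 1 (0.69 log units; beyond the scatter). How the core of compound 2 differs from the core of compound 3 is not broken down here. Compound 4 `CC(C)=CCC/C(C)=C/C[C@@H]1C[C@@]2(CC=C(C)C)C(=O)CC(=O)[C@](CC=C(C)C)(C2=O)C1(C)C` carries the same change on the core of compound 2: hydrogen in place of 3-methylbut-2-en-1-yl on a saturated chain carbon bound to a double-bonded chain carbon. The step from compound 2 to compound 4 is expected to be a step that the limit leaves unreadable from compound 2 to compound 4, because compound 2 already sits at the limit of > 20 ug/mL in this assay, at which 2 of the 3 values shown sit, and the same change weakened inhibition from compound 3 to compound 1. Compound 4 is therefore expected to give 40 ug/mL, between 20 ug/mL and 120 ug/mL.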

Compound 4, half-maximal inhibitory concentration: 6.89 ug/mL
Estimate against measurement, compound 4: 5.8-fold (0.76 log units) above; the measured number lies below the stated range.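

In this assay, putting hydrogen in place of 3-methylbut-2-en-1-yl on the core of compound 2 gave an at least 2.9-fold lower number from compound 2 to compound 4 (0.46 log units; beyond the scatter). This change therefore does not carry over from one core to the other in a fixed direction, as the two steps run opposite ways: the same change on two cores in this assay, an at least 4.9-fold higher number (0.69 log units; beyond the scatter) from compound 3 to compound 1 and an at least 2.9-fold lower number (0.46 log units; beyond the scatter) from compound 2 to compound 4, at least 14-fold (1.15 log units) apart, beyond the scatter of two such steps. It does not show why the two cores part ways, and each step gives only a minimum size, as the number at one end of each step is a limit of the assay rather than a measured number: the limit of > 20 ug/mL in this assay, at which 2 of the 4 values shown sit.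

The compounds shown leave open how a smaller group such as methyl, or an amine, would behave in that place on either core. From the compounds shown here alone, whether a third core would follow compound 2 or compound 3 also remains unknown.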